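This account rests on a few compounds, and the source may have more. Where it says the series, first, only, none or still open, it means among the compounds named here.

Measured so far:
- compound 1, `CN1C[C@H](C(=O)Nc2ccc(C#N)cc2)[C@@H](c2ccc(/C=C/C(=O)Nc3ccccc3N)cc2)C1`, with 1 mL/min/kg in an in vitro ADME assay on microsomes from liver (Homo sapiens) for pharmacokinetics, read by LC-MS, with a stated time of 10 min, tested at 1 uM; on this read-out lower numbers stand for slow clearance and higher numbers for fast clearance
- compound 2, `CN1C[C@H](C(=O)Nc2cccc(F)c2)[C@@H](c2ccc(/C=C/C(=O)Nc3ccccc3N)cc2)C1`, with 6 mL/min/kg in this assay

Going by the values given here, compound 2 sits at the higher of the two numbers in this assay; its nearest neighbour is compound 1, and the single step between them, a 6.0-fold higher number from compound 1 to compound 2 (0.78 log units; beyond the scatter), is beyond the scatter.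

Compound 3 is `CN1C[C@H](C(=O)Nc2cccnc2)[C@@H](c2ccc(/C=C/C(=O)Nc3ccccc3N)cc2)C1`. It differs from compound 2 in one place: pyridin-3-yl in place of 3-fluorophenyl on an amide-type nitrogen. Both compounds keep the shared core and the same amide-type nitrogen.

Among the compounds with values here, only one measured step exists here, a 6.0-fold higher number from compound 1 to compound 2 (0.78 log units; beyond the scatter), and it concerns a different exchange, 4-cyanophenyl to 3-fluorophenyl, so it bears on the present change only loosely. Within the data shown here, no measured step compares a pyridin-3-yl with a 3-fluorophenyl. With nothing pointing clearly either way, the expected outcome is a step of no more than the usual scatter, perhaps a slightly lower number: a 1.5-fold lower number from compound 2 to compound 3 (0.18 log units; within the scatter) is the expected step. Compound 3 is therefore estimated at 4 mL/min/kg in this assay, within a range from 1.5 mL/min/kg to 10 mL/min/kg.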

Compound 3, clearance: 10 mL/min/kg
For compound 3 the middle estimate is 2.5-fold (0.40 log units) below the measured one; the range from low to high includes it.
By their numbers in this assay, from the lowest: compound 1; then compounds 2 and 3 (each within the scatter of the next).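

Exchanging 3-fluorophenyl for pyridin-3-yl on the amide-type nitrogen gives no change that can be told apart in this assay (a 1.7-fold higher number from compound 2 to compound 3 (0.22 log units; within the scatter)), so at this place a carbon-only ring carrying fluorine and a ring with one hetero atom behave alike on this read-out. The other new step (a 10-fold higher number from compound 1 to compound 3 (1.00 log units; beyond the scatter)) is beyond the scatter and, taken with the earlier one (a 6.0-fold higher number from compound 1 to compound 2 (0.78 log units; beyond the scatter)), shows that the low number of compound 1 is not a peculiarity of a single comparison: among these three groups, 4-cyanophenyl alone stands apart, with the lowest number, while two different replacements both land clearly higher. Nothing available alongside these numbers accounts for why 4-cyanophenyl stands apart.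

The compounds shown do not separate the nitrile itself from the place it occupies on the ring, a question that 3-cyanophenyl or 4-fluorophenyl on the same nitrogen would address. On these data alone, it also stays open where unsubstituted phenyl or a saturated ring such as cyclohexyl would fall relative to these three groups.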